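Hydroxy replacing hydrogen on the aryl ether of compound 1

The source may report more compounds than this note shows. Statements on the series, on what has been measured and on what is new or still open speak of the compounds shown alone.

Measured compounds:
compound 1, `OC(CNCCOc1ccccc1)COc1ccccc1`: 0.054 mg/kg
compound 2, `COc1ccc(OCCNCC(O)COc2ccccc2)cc1`: 0.064 mg/kg
compound 3, `OC(CNCCOc1cccc(Cl)c1)COc1ccccc1`: 0.375 mg/kg

In a functional assay on the whole organism for inhibition, with Felis catus as the target, with a stated time of 30 min (on this read-out lower numbers stand for an effect already at smaller amounts and higher numbers for an effect only at larger amounts of compound), compound 1 gives 0.054 mg/kg, the lowest of the three numbers. Compound 2 stays within the scatter of compound 1 (a 1.2-fold higher number from compound 1 to compound 2 (0.07 log units; within the scatter)), whereas compound 3 lies beyond it (a 6.9-fold higher number from compound 1 to compound 3 (0.84 log units; beyond the scatter)). Compound 4, `Oc1ccc(OCC(O)CNCCOc2ccccc2)cc1`, differs from compound 1 by hydroxy in place of hydrogen on an aromatic carbon. The step from compound 1 to compound 2, a substituent entering para to a large group on the same six-membered aromatic ring of carbon only, is the one that bears on this change; it stayed within the scatter. Among the compounds with values here, no measured step covers hydroxy itself, so the expectation rests on that single comparison. Compound 4 is therefore expected near 0.07 mg/kg, range 0.03 mg/kg to 0.18 mg/kg, an estimated step of a 1.3-fold higher number from compound 1 to compound 4 (0.11 log units; within the scatter) that should stay within the scatter.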

Compound 4, dose for half-maximal effect: 0.031 mg/kg
Compound 4: the middle estimate sits 2.3-fold (0.35 log units) above what was measured; low and high end bracket the measured number.
By their numbers in this assay, from the lowest: compounds 4, 1 and 2 (each within the scatter of the next, the first and the last beyond it); then compound 3.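

Hydroxy on an aromatic carbon para to a large group gives a 1.7-fold lower number from compound 1 to compound 4 (0.24 log units; within the scatter) in this assay, so phenyl to 4-hydroxyphenyl leaves the number within the scatter of compound 1. Compound 4 is also the first in the series substituted on this aromatic ring, as compound 2 and compound 3 carry their substituents on the other one. No measurement on hand accounts for this result.

From the compounds shown here alone, whether an amine, a carboxylic acid or fluoro at this place would stay within the scatter remains open. So does whether methoxy or chloro on this ring would give the steps seen on the other ring.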